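Swapping the Ring on a Carbonyl Carbon

The source may hold more compounds than are shown below. What is called first, only, known or untested is meant among the compounds shown, and "the series" means these compounds.

Compound 1 `COc1cc(OC)c(OC)cc1/C=C/C(=O)c1cc(Cl)ccc1O` carries a carbonyl whose other neighbour is a double-bonded chain carbon, with an aromatic ring on each side. In a functional assay on SW982 cells (Homo sapiens) for inhibition, read by MTT assay, with a stated time of 72 h (on this read-out lower numbers stand for stronger inhibition and higher numbers for weaker inhibition), compound 1 gives only a limit, > 150000 nM, which is the edge of what the test reports rather than a number. Two companions set the scene. Compound 2 `COc1cc(OC)c(OC)cc1/C=C/C(=O)c1cccc([N+](=O)[O-])c1`, which shares the core with a different ring on the carbonyl, gives 101000 nM in this assay. Compound 3 `COc1cc(OC)c(-c2cc(=O)c3cc(Cl)ccc3o2)cc1OC`, in which the chain has closed into a ring, gives only a limit, > 150000 nM. Across these three, the limit of > 150000 nM in this assay, at which 2 of the 3 values shown sit, shows how little of the range has been mapped: the one genuine number is weak, and the rest sits at the boundary.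

Compound 4 `COc1ccc(C(=O)/C=C/c2cc(OC)c(OC)cc2OC)cc1` keeps the carbonyl and the double-bonded chain carbon of compound 1 and changes the ring on the carbonyl carbon: 4-methoxyphenyl in place of 5-chloro-2-hydroxyphenyl on a carbonyl carbon. Among the compounds with values here, no measured pair isolates this change, so the expectation rests only on the weakness seen in every compound here. The expected step of an at least 1.2-fold lower number from compound 1 to compound 4 (0.09 log units; that floor lies within the scatter) is taken to stay within the scatter. Compound 4 is therefore expected to give about 120000 nM, in a range from 40000 nM to 300000 nM, with a real chance that it again shows only a limit.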

Compound 4, half-maximal inhibitory concentration: 60500 nM
For compound 4 the middle estimate is 2.0-fold (0.30 log units) above the measured one; the range from low to high includes it.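

Within the data shown here, the ring on the carbonyl carbon is the first place in this set where a single change can be read: in this assay, 4-methoxyphenyl in place of 5-chloro-2-hydroxyphenyl gives an at least 2.4-fold lower number from compound 1 to compound 4 (0.39 log units; beyond the scatter), so this position does respond to a swap of ring, and compound 4 gives a real number rather than a limit. The value of compound 1, > 150000 nM, is a limit and not a number, so the step is only a floor for the true size of the change. Even with this gain, the response is far from mapped, and much of the set still rests on the edge of the test: the limit of > 150000 nM in this assay, at which 2 of the 4 values shown sit.

The swap removes the chlorine and the hydroxyl and adds the methoxy in one move, and the hydrogen-bond donor count changes with it, so this pair cannot say which of these parts accounts for the step. The compounds shown also leave open how the same carbonyl carbon would fare with a plain phenyl ring, or with a ring carrying an amine or a carboxylic acid.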